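Free fatty acid receptor 1 agonists: a substituent swap

The compounds below may be only part of what the source reports. "The series", "measured", "known", "first", "only" and "open" are said of these compounds alone.

In a functional assay on CHO cells for agonist activity at Free fatty acid receptor 1 (Homo sapiens), read by FLIPR and calcium flux, in the presence of a further agent that is not named here (a higher number here means that more compound is needed for the effect, a lower number that less compound is needed), compound 3 `Cc1cc(-c2noc(COc3ccc(CCC(=O)O)cc3)n2)ccc1F` gives 2120 nM, the lowest number among the three measured compounds. Compound 1 `Cc1cccc(-c2noc(COc3ccc(CCC(=O)O)cc3Cl)n2)c1` gives 4580 nM, a gap beyond the scatter, and compound 2 `O=C(O)CCc1ccc(OCc2ncc(-c3cccc(Cl)c3)o2)cc1` gives 47500 nM, much further away. Compound 4 `O=C(O)CCc1ccc(OCc2nc(-c3ccc(Cl)cc3)no2)cc1` has not been measured in this assay; it differs from compound 3 in one place: 4-chlorophenyl in place of 4-fluoro-3-methylphenyl on an aromatic carbon. Because compound 1, which keeps the methyl but lacks the fluorine, gives 4580 nM, a change that removes both is expected to raise the number somewhat. Compound 4 is therefore expected to give about 5000 nM, within a range of 2000 nM to 13000 nM. The expected step of a 2.4-fold higher number from compound 3 to compound 4 (0.37 log units; beyond the scatter) is upward, just beyond the scatter.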

Compound 4, half-maximal effective concentration: 540 nM
Beside the measured number, compound 4's estimate is 9.3-fold (0.97 log units) above it; measured number outside the range, below it.
By their numbers in this assay, from the lowest: compound 4; then compound 3; then compound 1; then compound 2.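

On the aromatic carbon between two ring nitrogen atoms, 4-chlorophenyl in place of 4-fluoro-3-methylphenyl gives a 3.9-fold lower number from compound 3 to compound 4 (0.59 log units; beyond the scatter) and so lowers the number needed, a modest step beyond the scatter. This position therefore responds to the substituents on its phenyl ring, and losing the methyl does not cost activity when chlorine replaces fluorine. No measurement shown here accounts for the step.

As far as these compounds go, because the halogen and the methyl change together, their separate shares remain open. So does the outcome with 4-bromophenyl or 4-methoxyphenyl at this position.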